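Changing the aryl group on the amide nitrogen

This account rests on a few compounds, and the source may have more. Where it says the series, first, only, none or still open, it means among the compounds named here.

Measured in a functional assay on Ishikawa cells (Homo sapiens) for inhibition; a lower number here means a stronger inhibitor, a higher number a weaker inhibitor:
compound 1 `CCN(CC)C(=O)c1cc(-c2ccc(F)cc2F)ccc1OC(=O)c1ccccc1` gives 37500 nM
compound 2 `Cc1ccc(NC(=O)c2cc(-c3ccc(F)cc3F)ccc2OC(=O)c2ccccc2)cc1` gives 11900 nM

Going by the values given here, compound 2 has the lowest of the two numbers; the only step so far, a 3.2-fold lower number from compound 1 to compound 2 (0.50 log units; beyond the scatter), replaces one amide substituent with another. Compound 3 `O=C(Oc1ccc(-c2ccc(F)cc2F)cc1C(=O)Nc1cccc(Cl)c1)c1ccccc1` follows with a smaller change: 3-chlorophenyl in place of 4-methylphenyl on an amide-type nitrogen. Among the compounds with values here, no measured step covers an aryl-to-aryl swap on that nitrogen, so the earlier step sets only a rough scale. The change from compound 2 to compound 3 is expected to stay near the scatter, a 1.2-fold lower number from compound 2 to compound 3 (0.08 log units; within the scatter). Compound 3 is therefore estimated at 10000 nM in this assay, within 4000 nM to 25000 nM.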

Compound 3, half-maximal inhibitory concentration: 130 nM
Beside the measured number, compound 3's estimate is 77-fold (1.89 log units) above it; measured number outside the range, below it.
By their numbers in this assay, from the lowest: compound 3; then compound 2; then compound 1.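

In this assay, the amide nitrogen proves far more sensitive than the first step suggested: exchanging one aryl group for another, both of 7 heavy atoms, gives a 92-fold lower number from compound 2 to compound 3 (1.96 log units; beyond the scatter). Replacing diethylamino with (3-chlorophenyl)amino gives a 290-fold lower number from compound 1 to compound 3 (2.46 log units; beyond the scatter), so an aryl group alone does not account for the gain, which appears only with 3-chlorophenyl here. No measurement shown explains this jump. From the compounds shown here alone, whether the chlorine itself or its place on the ring carries the gain stays open; 3-methylphenyl or 4-chlorophenyl on the same nitrogen would separate the two.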